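Swapping the aryl group on a piperazine nitrogen

The source may report more compounds than this note shows. Statements on the series, on what has been measured and on what is new or still open speak of the compounds shown alone.

Three measured compounds share one core and differ only in the aromatic group attached to an amine nitrogen in a ring. Compound 1 `CC1(c2ccc(F)cc2)NC(=O)N(CC(O)CN2CCN(c3ccccc3F)CC2)C1=O` gives 234 nM in an assay on HEK293 cells for displacement of a labelled ligand from 5-hydroxytryptamine receptor 7 (Homo sapiens); a lower number here means a stronger inhibitor, a higher number a weaker inhibitor. Compound 2 `CCOc1ccccc1N1CCN(CC(O)CN2C(=O)NC(C)(c3ccc(F)cc3)C2=O)CC1` gives 10 nM in this assay, and compound 3 `CC1(c2ccc(F)cc2)NC(=O)N(CC(O)CN2CCN(c3ccc(F)cc3F)CC2)C1=O` gives 1190 nM in this assay. Compound 3 therefore stands at the top of the three numbers and is the weakest binder of the set: there is a 5.1-fold higher number from compound 1 to compound 3 (0.71 log units; beyond the scatter), and there is a 120-fold higher number from compound 2 to compound 3 (2.08 log units; beyond the scatter).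

Compound 4 `CC1(c2ccc(F)cc2)NC(=O)N(CC(O)CN2CCN(c3ccc(Cl)c(Cl)c3)CC2)C1=O` has not yet been measured. It differs from compound 3 in one place: 3,4-dichlorophenyl in place of 2,4-difluorophenyl on an amine nitrogen in a ring. The two measured steps that bear on this place are those leading into compound 3. The smaller one, a 5.1-fold higher number from compound 1 to compound 3 (0.71 log units; beyond the scatter), came from a single added fluoro; the larger one, a 120-fold higher number from compound 2 to compound 3 (2.08 log units; beyond the scatter), came from exchanging the whole aromatic group. Both show that the group at this place can move the number a great deal, yet neither tests a chlorine nor a 3,4-dichlorophenyl, so the direction is uncertain. On balance, a modest downward step is expected, a 2.4-fold lower number from compound 3 to compound 4 (0.38 log units; beyond the scatter), close to the edge of the scatter. Compound 4 is thus expected to give about 500 nM in this assay, with a likely range from 100 nM to 3000 nM.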

Compound 4, inhibition constant: 141 nM
Estimate against measurement, compound 4: 3.5-fold (0.55 log units) above, within the range that was stated.
By their numbers in this assay, from the lowest: compound 2; then compounds 4 and 1 (each within the scatter of the next); then compound 3.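

Exchanging the 2,4-difluorophenyl group for 3,4-dichlorophenyl gives an 8.4-fold lower number from compound 3 to compound 4 (0.93 log units; beyond the scatter) in this assay, so a phenyl ring bearing two halogen atoms is not tied to the high number of compound 3. Set against the 2-fluorophenyl group, the new group gives a 1.7-fold lower number from compound 1 to compound 4 (0.22 log units; within the scatter) and the two cannot be ranked, while set against the 2-ethoxyphenyl group it gives a 14-fold higher number from compound 2 to compound 4 (1.15 log units; beyond the scatter) and leaves compound 2 with the lowest number of the four. Among these four compounds, then, the ethoxy-bearing ring stands apart, and no data shown here give a reason for any of these differences.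

The step from compound 3 to compound 4 changes both the halogen and where it sits on the ring, so the compounds shown cannot say how much of the change belongs to chlorine itself and how much to its place. Also open, from the compounds shown here alone, is how a phenyl group carrying a single chlorine, or a methoxy group or a longer propoxy chain in place of the ethoxy group of compound 2, would fare in this assay at this position.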